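Pyridin-3-yl for Pyridin-4-yl: An Expected Step

The source may hold more compounds than are shown below. What is called first, only, known or untested is meant among the compounds shown, and "the series" means these compounds.

Compound 1 `Cc1cn2c(/C=N/NC(=N)N)c(-c3ccncc3)nc2s1` gives 47900 nM in a functional assay (Homo sapiens) for antiproliferative activity; on this read-out lower numbers stand for stronger inhibition of growth and higher numbers for weaker inhibition of growth. Going by the values given here, the only other measured compound, compound 2 `Cc1sc2nc(-c3ccncc3)c(/C=N/NC(=N)N)n2c1C`, gives 91200 nM in this assay, and the step of a 1.9-fold higher number from compound 1 to compound 2 (0.28 log units; within the scatter) lies within the scatter, so the two numbers cannot be told apart. Compound 3 `Cc1cn2c(/C=N/NC(=N)N)c(-c3cccnc3)nc2s1` differs from compound 1 by pyridin-3-yl in place of pyridin-4-yl on an aromatic carbon. Among the compounds with values here, no measured pair bears on this change: the single step available, from compound 1 to compound 2, concerns a methyl in place of hydrogen on an aromatic carbon and says nothing about exchanging pyridin-4-yl for pyridin-3-yl. Within the data shown here, with only two measured compounds, the expectation for compound 3 rests on compound 1 alone, and the step of a 1.0-fold higher number from compound 1 to compound 3 (0.02 log units; within the scatter) is expected to remain within the scatter, in no particular direction. Compound 3 is therefore estimated at 50000 nM in this assay, with a range from 15000 nM to 160000 nM.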

Compound 3, concentration for total growth inhibition: 22400 nM
Compound 3: the middle estimate sits 2.2-fold (0.35 log units) above what was measured, within the range that was stated.
By their numbers in this assay, from the lowest: compound 3; then compounds 1 and 2 (each within the scatter of the next).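

Exchanging pyridin-4-yl for pyridin-3-yl, two groups with the same counts of heavy atoms, hydrogen-bond donors and acceptors, gives a 2.1-fold lower number from compound 1 to compound 3 (0.33 log units; beyond the scatter) in this assay. Going by these compounds alone, this is the first step to lie beyond the scatter, though only modestly, so the read-out responds to which pyridinyl group sits on this aromatic carbon, whereas the methyl step, a 1.9-fold higher number from compound 1 to compound 2 (0.28 log units; within the scatter), could not be told apart. No evidence is available to explain this difference.

On these data alone, whether pyridin-2-yl or a plain phenyl ring on the same aromatic carbon would give a lower or a higher number remains open. So does whether the gain from pyridin-3-yl would carry over to the core of compound 2, with its extra methyl.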